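Compound 4 after the loss of the dimethyl-oxazole

The source may report more compounds than this note shows. Statements on the series, on what has been measured and on what is new or still open speak of the compounds shown alone.

Measured in a functional assay on KARPAS-422 cells (Homo sapiens) for antiproliferative activity, read by resazurin assay, with a stated time of 72 h; a higher number here means a weaker inhibitor, a lower number a stronger inhibitor:
- compound 1 `Cc1cc(C)c(CN2CCc3c(Cl)cc(C(CO)C4CCOC4)c(Cl)c3C2=O)c(=O)[nH]1` gives 1040 nM; 17 nM (2 entries)
- compound 2 `Cc1cc(C)c(CN2CCc3c(Cl)cc([C@@H](CO)[C@@H]4CCCO4)c(Cl)c3C2=O)c(=O)[nH]1` gives 1220 nM
- compound 3 `Cc1cc(C)c(CN2CCc3c(Cl)cc(-c4c(C)noc4C)c(Cl)c3C2=O)c(=O)[nH]1` gives 23 nM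

Compound 3 holds the lower of the two single numbers, and compound 1 has no single value. For the measured compounds named here, the only measured step is a 53-fold lower number from compound 2 to compound 3 (1.72 log units; beyond the scatter) and bears directly on what follows. Compound 4 `Cc1cc(C)c(CN2CCc3c(Cl)cc([C@@H](CO)[C@H]4CCCO4)c(Cl)c3C2=O)c(=O)[nH]1` arises from compound 3 by one change a group of 8 heavy atoms (6 carbon, 2 oxygen; one five-membered non-aromatic ring with 1 hetero atom) in place of a group of 7 heavy atoms (5 carbon, 1 nitrogen, 1 oxygen; one five-membered aromatic ring with 2 hetero atoms), on an aromatic carbon on an aromatic carbon. This runs against that step, so a higher number is expected. Going by these compounds, the size stays open, as the several entries of compound 1 in this assay, 1040 nM; 17 nM (2 entries) spans a wide range for a single structure. The expected step in this assay is a 6.5-fold higher number from compound 3 to compound 4 (0.81 log units; beyond the scatter) with a wide margin. Compound 4 is estimated at 150 nM (expected range 15 nM to 1500 nM).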

Compound 4, half-maximal inhibitory concentration in the KARPAS-422 assay: 535 nM
Estimate against measurement, compound 4: 3.6-fold (0.55 log units) below; the range from low to high includes it.
By their numbers in the KARPAS-422 assay, from the lowest: compound 3; then compound 4; then compound 2.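

In the KARPAS-422 assay the change at this aromatic carbon brings a 23-fold higher number from compound 3 to compound 4 (1.37 log units; beyond the scatter), so compound 4 gives up much of the potency of compound 3. In the KARPAS-422 assay configuration alone also moves the number at this position, with a 2.3-fold lower number from compound 2 to compound 4 (0.36 log units; beyond the scatter), and this shift can be assigned to the stereocentre at the saturated ring carbon: the fact that compounds 2 and 4 differ only in the configuration as drawn

In a physicochemical assay for solubility, measured as kinetic solubility (a lower number here means a less soluble compound, a higher number a more soluble compound), compound 3 gives 93000 nM and compound 4 gives 576000 nM, so the same change comes with higher solubility: the measured solubility of compound 3, 93000 nM, and of compound 4, 576000 nM, a 6.2-fold higher number (0.79 log units; beyond the scatter)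

Going by these compounds, it remains open whether an amine or a carboxylic acid on this carbon could combine the potency of compound 3 with the solubility of compound 4. The value of compound 1 also stays unsettled: the several entries of compound 1 in the KARPAS-422 assay, 1040 nM; 17 nM (2 entries)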